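Amide and ester variation at the carbonyl carbon

A few compounds are considered here, and "the series" means these few. Any claim that something is new, unique, unknown or untested is made for them only; others in the source may bear on it.

Compound 1, `NC(=O)/C=C/c1ccncc1-c1ccc2ccccc2c1`: in a functional assay on KB cells (Homo sapiens) for inhibition, read by sulforhodamine B assay, with a stated time of 72 h (on this read-out lower numbers stand for stronger inhibition of growth and higher numbers for weaker inhibition of growth), compound 1 gives a limit, > 10000 nM.
Compound 2, `COC1CN(C(=O)/C=C/c2ccncc2-c2ccc3ccccc3c2)C1`: compound 2 also stops at a limit, > 10000 nM.
Compound 3, `COC(=O)/C=C/c1ccncc1-c1ccc2ccccc2c1`: compound 3 gives 6730 nM.

Within the data shown here, compound 3 thus holds the only number in the set; the other two values are limits, as the limit of > 10000 nM in this assay, at which 2 of the 3 values shown sit, records. Compound 4, `CN1CCN(C(=O)/C=C/c2ccncc2-c2ccc3ccccc3c2)CC1`, carries 4-methylpiperazin-1-yl in place of methoxy on a carbonyl carbon. Among the measured compounds shown here, two measured steps bear on it, both running toward compound 3: an at least 1.4-fold lower number from compound 1 to compound 3 (0.17 log units; that floor lies within the scatter) and an at least 1.4-fold lower number from compound 2 to compound 3 (0.17 log units; that floor lies within the scatter), each only a floor that lies within the scatter. Compound 4 moves back from methoxycarbonyl to a nitrogen-linked group of the kind seen in compound 1 and compound 2, so a step to a higher number is expected, a 2.2-fold higher number from compound 3 to compound 4 (0.35 log units; beyond the scatter), with a real chance of a limit. Compound 4 is expected at 15000 nM, between 5000 nM and 40000 nM.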

Compound 4, concentration for 50% growth inhibition: > 10000 nM
Compound 4: a limit, no number; the forecaster's own chance of this, stated with the estimate: 60%; the middle value is on the limit's open side.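

In this assay a larger nitrogen-linked group with a six-membered ring, 4-methylpiperazin-1-yl, also gives only a limit on the carbonyl carbon, so the change reads as an at least 1.4-fold higher number from compound 3 to compound 4 (0.17 log units; that floor lies within the scatter). The steps among compound 1, compound 2 and compound 4 cannot be read, so these three groups cannot be ranked. Methoxy in compound 3 remains the only group here with a number, and the limit now covers most of the set: the limit of > 10000 nM in this assay, at which 3 of the 4 values shown sit.

From the compounds shown here alone, whether methoxy truly differs from the nitrogen-linked groups remains open, since the only readable floors lie within the scatter. Also open, going by these compounds, is how an ethoxy ester or a carboxylic acid at this carbonyl carbon would read.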